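The source may hold more compounds than are shown below. What is called first, only, known or untested is meant among the compounds shown, and "the series" means these compounds.

In a functional assay on SK-OV-3 cells (Homo sapiens) for cytotoxicity (on this read-out lower numbers stand for stronger inhibition of growth and higher numbers for weaker inhibition of growth), compound 1 `CSc1ccc(C2=C(c3ccc(C)c(C)c3)C(=O)N3CCCC3C2)cc1` gives 300 nM. Compound 2 `CSc1ccc(C2=C(c3ccc(O)cc3)C(=O)N3CCCC3C2)cc1` gives > 100000 nM, which is a limit and not a number. Among the measured compounds shown here, the one measured step, an at least 330-fold higher number from compound 1 to compound 2 (2.52 log units; beyond the scatter), is large and came with 4-hydroxyphenyl in place of 3,4-dimethylphenyl on a double-bonded ring carbon. Compound 3 `CSc1ccc(C2=C(c3ccc(F)cc3)C(=O)N3CCCC3C2)cc1` carries fluoro in place of hydroxy on an aromatic carbon. For the measured compounds named here, on that single step, the number in this assay is expected to fall back most of the way toward that of compound 1, though the data hold no direct precedent for fluoro. The expected change is large and toward a lower number: an at least 66-fold lower number from compound 2 to compound 3 (1.82 log units; beyond the scatter). For compound 3 the estimate is 1500 nM, with an expected range of 250 nM to 15000 nM.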

Compound 3, concentration for 50% growth inhibition: 30000 nM
The estimate for compound 3 lay 20-fold (1.30 log units) below the measured number; measured number above the stated range.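

Fluoro in place of hydroxy on the aromatic carbon para to a large group brings measurable growth inhibition back in this assay (an at least 3.3-fold lower number from compound 2 to compound 3 (0.52 log units; beyond the scatter)). Compound 2 stands only as a limit and not a number: the limit of > 100000 nM in this assay, at which 1 of the 3 values shown sits. Even so, 4-fluorophenyl remains far behind 3,4-dimethylphenyl on the double-bonded ring carbon (a 100-fold higher number from compound 1 to compound 3 (2.00 log units; beyond the scatter)), so removing the hydroxy alone does not recover the level of compound 1. Still open, on these data alone, is how a 4-methylphenyl, 3-methylphenyl or 4-chlorophenyl group would compare here, and so whether one methyl suffices.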